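A few compounds are considered here, and "the series" means these few. Any claim that something is new, unique, unknown or untested is made for them only; others in the source may bear on it.

Compound 3 `CC/N=C(\S)NCCCn1nc(-c2ccccc2)ccc1=O` stands second highest of the three numbers in a functional assay on the whole organism with Rattus norvegicus as the target, at a dose of 100 mg/kg (a lower number here means less inhibition, a higher number more inhibition at the dose given (going by the name of the read-out)), where compound 3 gives 39%. Its nearest neighbour is compound 1 `N#CNC(=N)NCCCCCn1nc(-c2ccccc2)ccc1=O`, which gives 31%, the pair separated only by a number 8 percentage points higher from compound 1 to compound 3 (within the scatter). Furthest away is compound 2 `CN(C)/C(=N/CCCCn1nc(-c2ccccc2)ccc1=O)NC#N`, which gives 80.7%; the step of a number 49.7 percentage points higher from compound 1 to compound 2 (beyond the scatter) was large. Compound 4 `C=CCNC(=S)NCCCCn1nc(-c2ccccc2)ccc1=O` differs from compound 3 by a group of 8 heavy atoms (5 carbon, 2 nitrogen, 1 sulfur; no ring) in place of a group of 6 heavy atoms (3 carbon, 2 nitrogen, 1 sulfur; no ring), on a saturated chain carbon, three bonds along the chain from an aromatic nitrogen. Going by the values given here, the step bearing most directly on this change is the one from compound 1 to compound 3, made at the same place along the chain, and it stayed within the scatter; the large step to compound 2 concerned a different group. A small step, if any, is therefore expected: a number 6 percentage points higher from compound 3 to compound 4 (within the scatter). Compound 4 is accordingly estimated at 45%, between 25% and 70%.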

Compound 4, a percentage reported as inhibition, in the whole organism at one dose (the size of the read-out at that dose, not a potency): 27.1%
For compound 4 the middle estimate is 17.9 percentage points above the measured one; measured number inside the range.
By their numbers in this assay, from the lowest: compounds 4, 1 and 3 (each within the scatter of the next, the first and the last beyond it); then compound 2.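

In this assay, the larger sulfur-containing group at this place brought a number 11.9 percentage points lower from compound 3 to compound 4 (beyond the scatter), so this change did shift the number, though modestly. Exchanging a four-nitrogen group for a sulfur-containing group gave a number 3.9 percentage points lower from compound 1 to compound 4 (within the scatter) in one pair, but a number 53.6 percentage points lower from compound 2 to compound 4 (beyond the scatter) in the other, so the high number remains confined to a single compound. Nothing available explains these steps. As far as these compounds go, whether a simple amine or a carboxylic acid at the chain end would give a higher or lower number remains open, as does the outcome for a longer chain carrying the sulfur-containing group.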